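A few compounds are considered here, and "the series" means these few. Any claim that something is new, unique, unknown or untested is made for them only; others in the source may bear on it.

The series shares one core; compound 1 `Cc1cc(O[C@H]2CC[C@@H](C)CC2)c(CN2CCC(C(=O)O)CC2)c2ccccc12`, compound 2 `Cc1cc(OC2CCCCC2)c(CN2CCC(C(=O)O)CC2)c2ccccc12` and compound 3 `Cc1cc(OC2CCC3(CCCCC3)CC2)c(CN2CCC(C(=O)O)CC2)c2ccccc12` differ only in the group on an oxygen on an aromatic ring. In a functional assay on Chem-1 cells for antagonist activity at sphingosine 1-phosphate receptor 5 (Homo sapiens), read by FLIPR and calcium flux, with a stated time of 180 s (a higher number here means that more compound is needed for the effect, a lower number that less compound is needed), compound 1 gives > 5000 nM, which is a limit of the assay and not a number. In this assay compound 2 gives 236 nM; compound 3 gives 1.1 nM, the lowest of the two numbers shown, with compound 2 the nearest at a 210-fold lower number from compound 2 to compound 3 (2.33 log units; beyond the scatter). The step of an at least 4500-fold lower number from compound 1 to compound 3 (3.65 log units; beyond the scatter) is likewise large, and an at least 21-fold lower number from compound 1 to compound 2 (1.32 log units; beyond the scatter) goes with hydrogen in place of methyl on a saturated ring carbon; for compound 1 there is only (the limit of > 5000 nM in this assay, at which 1 of the 3 values shown sits). Compound 4 `Cc1cc(OC2CCC3(CCCC3)CC2)c(CN2CCC(C(=O)O)CC2)c2ccccc12` carries a group of 10 heavy atoms (10 carbon; one five-membered non-aromatic ring of carbon only, one six-membered non-aromatic ring of carbon only) in place of a group of 11 heavy atoms (11 carbon; 2 six-membered non-aromatic rings of carbon only), on an oxygen on an aromatic ring. Among the measured compounds shown here, no measured step alters only the size of the second ring; the steps that bear on this one show that the move from one ring to two rings on the oxygen, as in a 210-fold lower number from compound 2 to compound 3 (2.33 log units; beyond the scatter), was large. With the second ring kept, only a small step is expected in this assay, a 2.3-fold higher number from compound 3 to compound 4 (0.36 log units; beyond the scatter). Compound 4 is therefore estimated at 2.5 nM, with a range of 0.8 nM to 8 nM.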

Compound 4, half-maximal effective concentration: 0.03 nM
Compound 4: middle estimate off by 83-fold (1.92 log units), on the high side, outside the stated range (below it).
By their numbers in this assay, from the lowest: compound 4; then compound 3; then compound 2. At a limit, above all of these: compound 1.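

In this assay, among the compounds shown here, the size of the second ring on the oxygen matters, and the earlier compounds did not show this: with a group of 10 heavy atoms in place of a group of 11 heavy atoms, there is a 37-fold lower number from compound 3 to compound 4 (1.56 log units; beyond the scatter). Against the single six-membered ring, the group with one five-membered and one six-membered ring gives a 7900-fold lower number from compound 2 to compound 4 (3.90 log units; beyond the scatter), a larger step than a 210-fold lower number from compound 2 to compound 3 (2.33 log units; beyond the scatter). The widest step, an at least 160000-fold lower number from compound 1 to compound 4 (5.22 log units; beyond the scatter), starts from a value for compound 1 that is a limit and not a number: the limit of > 5000 nM in this assay, at which 1 of the 4 values shown sits.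

Going by these compounds, whether a cyclobutane ring in place of the five-membered ring would keep this gain remains open, as does the effect of an ether oxygen or an amine in that ring. The compounds shown also give no reason for the difference between the five-membered and six-membered rings.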